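The compounds below may be only part of what the source reports. "The series", "measured", "known", "first", "only" and "open" are said of these compounds alone.

Measured compounds:
- Compound 1, `COc1cc(Nc2ncnc3c(NC(=O)Nc4cccc(Oc5ccccc5)c4)cccc23)cc(OC)c1`: 14000 nM
- Compound 2, `COc1cc(Nc2ncnc3c(NC(=O)Nc4ccc(C)c(C)c4)cccc23)cc(OC)c1`: 8.8 nM

Both compounds were tested in a functional assay on RT-112 cells (Homo sapiens) for antiproliferative activity, read by MTT assay, with a stated time of 72 h; on this read-out lower numbers stand for stronger inhibition of growth and higher numbers for weaker inhibition of growth. In this assay compound 1 gives 14000 nM, while compound 2 gives 8.8 nM. Compound 2 therefore stands at the lowest of the two numbers, and its distance from compound 1 is far beyond the scatter, so compound 2 is clearly the stronger inhibitor of growth of the two.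

The next compound, compound 3, `COc1cc(Nc2ncnc3c(NC(=O)Nc4cc(Cl)cc(Cl)c4)cccc23)cc(OC)c1`, has not yet been measured. It differs from compound 2 in one place: 3,5-dichlorophenyl in place of 3,4-dimethylphenyl on an amide-type nitrogen. The shared core, the urea linkage and the dimethoxyphenyl part stay the same; only the ring on the far side of the urea is exchanged for another ring of the same counted size.

Going by the values given here, no step between two measured compounds has the same kind of change, so the expectation rests on compound 2 alone, whose value 8.8 nM sets the starting point. A small step, no more than about the scatter, toward a weaker or equal inhibition is expected. Compound 3 is estimated at 18 nM, with a range from 4 nM to 120 nM. That estimate corresponds to an expected step of a 2.0-fold higher number from compound 2 to compound 3 (0.31 log units; beyond the scatter).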

Compound 3, concentration for 50% growth inhibition: 30.2 nM
Compound 3: the middle estimate sits 1.7-fold (0.22 log units) below what was measured; low and high end bracket the measured number.
By their numbers in this assay, from the lowest: compound 2; then compound 3; then compound 1.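

Exchanging 3,4-dimethylphenyl for 3,5-dichlorophenyl on the amide-type nitrogen of the urea gives a 3.4-fold higher number from compound 2 to compound 3 (0.54 log units; beyond the scatter) in this assay. This shows that the position responds to the exchange even though the two rings have the same heavy-atom count and the same zero counts of hydrogen-bond donors and acceptors, while the change in the number is modest and compound 3 still gives 30.2 nM. No measurement shown here explains the difference between these two compounds.

This single step changes two things: methyl groups give way to chlorine atoms, and the ring's substitution pattern changes from that of 3,4-dimethylphenyl to that of 3,5-dichlorophenyl, so the compounds shown cannot say how much of the step belongs to each. They also leave open how the growth-inhibition number would respond to a ring carrying an amine or a carboxylic acid at this position, since both rings compared here carry only methyl groups or chlorine atoms.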